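Compound 2 to compound 4: a second amide

The compounds below may be only part of what the source reports. "The series", "measured", "known", "first", "only" and "open" are said of these compounds alone.

Measured so far:
- compound 1 `Cc1c(C)c2c(c(C)c1OC(=O)CCC(=O)O)CCC(C)(C(=O)NC1CC(C)(C)N([O])C(C)(C)C1)O2` gives 165000 nM
- compound 2 `Cc1c(C)c2c(c(C)c1OC(=O)CCC(=O)O)CCC(C)(C(=O)NCC1CC(C)(C)N([O])C1(C)C)O2` gives > 300000 nM (a limit)
- compound 3 `Cc1c(C)c2c(c(C)c1OC(=O)CCC(=O)O)CCC(C)(C(=O)O)O2` gives 285000 nM

In a functional assay on MT4 cells (Homo sapiens) for cytotoxicity, read by MTT assay, with a stated time of 72 h (on this read-out lower numbers stand for stronger inhibition and higher numbers for weaker inhibition), compound 2 stands at a limit and not at a number (> 300000 nM).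

Compound 4 `Cc1c(C)c2c(c(C)c1OC(=O)CCC(=O)NCC1CC(C)(C)N([O])C1(C)C)CCC(C)(C(=O)NCC1CC(C)(C)N([O])C1(C)C)O2` differs from compound 2 by one change (a group of 12 heavy atoms (9 carbon, 2 nitrogen, 1 oxygen; one five-membered non-aromatic ring with 1 hetero atom) in place of one oxygen atom, on a carbonyl carbon). The hydroxy leaves, and the entering group sits on a carbonyl carbon with a saturated chain carbon as its other neighbour.

The closest measured change is the same kind of exchange on another carbonyl carbon (an at least 1.0-fold lower number from compound 2 to compound 3 (0.02 log units; that floor lies within the scatter)). The two remaining steps (an at least 1.8-fold higher number from compound 1 to compound 2 (0.25 log units; that floor lies within the scatter) and a 1.7-fold higher number from compound 1 to compound 3 (0.24 log units; within the scatter)) also stay within the scatter. Going by the values given here, no step in the set goes beyond the scatter, and two of the three rest on a limit only.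

On these steps no change beyond the scatter is expected in this assay and no firm direction can be given. The estimated step is small (an at least 1.5-fold lower number from compound 2 to compound 4 (0.17 log units; that floor lies within the scatter)).

The expected value for compound 4 is 200000 nM (estimated range 80000 nM to 300000 nM).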

Compound 4, half-maximal inhibitory concentration: 114000 nM
The estimate for compound 4 lay 1.8-fold (0.24 log units) above the measured number; the range from low to high includes it.
By their numbers in this assay, from the lowest: compounds 4, 1 and 3 (each within the scatter of the next, the first and the last beyond it). At a limit, above all of these: compound 2.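

In this assay, going by these compounds alone, the exchange of the hydroxy for the group of 12 heavy atoms with its five-membered non-aromatic ring, on a carbonyl carbon with a saturated chain carbon as its other neighbour, is the only step in the set that goes beyond the scatter: an at least 2.6-fold lower number from compound 2 to compound 4 (0.42 log units; beyond the scatter). The earlier exchanges, all on the other carbonyl carbon, stayed within the scatter, so this place is the only one in the set where such a change shows up in this assay. Compound 2 stands at a limit, so the step gives a floor and not a size: the limit of > 300000 nM in this assay, at which 1 of the 4 values shown sits.

As far as these compounds go, it remains open whether the change at this place needs the five-membered ring group, or whether a simple amine, a longer chain or the six-membered ring group of compound 1 on the same carbonyl carbon would give a step of like size. From the compounds shown here alone, it also remains open how far the true distance of the step reaches, and whether a group on this carbonyl carbon alone, with a carboxylic acid on the other carbonyl carbon, would behave in the same way.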